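A few compounds are considered here, and "the series" means these few. Any claim that something is new, unique, unknown or untested is made for them only; others in the source may bear on it.

Working notes, series of sulfonyl hydrazides. Compound 1 `Cc1cc(-n2cccn2)cc(C(=O)NNS(=O)(=O)c2ccccc2)c1F` gives 567 uL/min in an ADME assay on microsomes from liver (Mus musculus) for metabolic stability, read by HPLC, using NADPH, with a stated time of 60 min, tested at 1 uM, in the presence of a further agent that is not named here (a lower number here means slower removal, a higher number faster removal of the compound), compound 2 `Cc1cc(-c2ccccn2)cc(C(=O)NNS(=O)(=O)c2ccccc2)c1F` gives 424 uL/min, and compound 3 `O=C(NNS(=O)(=O)c1ccccc1F)c1cccc(-n2cccn2)c1` gives 178 uL/min. Compound 2 stands second highest of the three numbers; its values and those of compound 1 lie within the scatter of each other, while compound 3 shows a lower number. Compound 4 `C=CCOc1cc(C)c(F)c(C(=O)NNS(=O)(=O)c2ccccc2)c1` differs from compound 2 by allyloxy in place of pyridin-2-yl on an aromatic carbon. For the measured compounds named here, the only single-point step recorded, a 1.3-fold lower number from compound 1 to compound 2 (0.13 log units; within the scatter), is within the scatter and swaps one ring for another ring, whereas here a ring leaves and allyloxy enters; compound 3 differs in several places and gives no step. Going by the values given here, no measured step therefore bears directly on this change. The estimate for compound 4 is 450 uL/min, in the range 200 uL/min to 1000 uL/min; the expected step of a 1.1-fold higher number from compound 2 to compound 4 (0.03 log units; within the scatter) is none beyond the scatter.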

Compound 4, intrinsic clearance in a liver preparation (reported as CLH), per the amount of preparation that the assay uses: > 866 uL/min
Compound 4: only a limit was reported; the forecaster's own chance of this, stated with the estimate: 5%; middle value at least 1.9-fold (0.28 log units) away from the limit.
By their numbers in this assay, from the lowest: compound 3; then compounds 2 and 1 (each within the scatter of the next). At a limit, above all of these: compound 4.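

Compound 4 gives > 866 uL/min in this assay, which is a limit and not a number. Allyloxy gives an at least 2.0-fold higher number from compound 2 to compound 4 (0.31 log units; beyond the scatter) at this position, so this open-chain group moves the number beyond the scatter, which the swap of one ring for another did not do. The comparison with 1H-pyrazol-1-yl is less firm, with an at least 1.5-fold higher number from compound 1 to compound 4 (0.18 log units; that floor lies within the scatter) as its step.

As far as these compounds go, the true size of both steps stays open. Also open, from the compounds shown here alone, is whether the double bond or the loss of the ring carries the change; a saturated propoxy chain or an amine at this position would help separate these.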